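The source may report more compounds than this note shows. Statements on the series, on what has been measured and on what is new or still open speak of the compounds shown alone.

Compound 1 `COc1ccc(S(=O)(=O)N(CCn2cc(CN(C)S(=O)(=O)c3ccc(F)cc3)nn2)[C@@H](C(=O)NO)C(C)C)cc1`: 3 nM
Compound 2 `CC(C)[C@H](C(=O)NO)N(CCn1cc(COCCOCCOCCOCCOCCF)nn1)S(=O)(=O)c1ccc(OCCF)cc1`: 10 nM
Compound 3 `CC(C)[C@H](C(=O)NO)N(Cc1cn(CCOCCOCCOCCF)nn1)S(=O)(=O)c1ccc(OCCF)cc1`: 0.2 nM

In an assay on isolated protein for inhibition of matrix metalloproteinase-9 (Homo sapiens), read by fluorescence, with a stated time of 30 min (on this read-out higher numbers stand for weaker inhibition and lower numbers for stronger inhibition), compound 3 gives 0.2 nM, the lowest of the three numbers. Compound 1 sits well above it, and compound 2 higher still; both gaps lie beyond the usual scatter. Compound 4 `CC(C)[C@H](C(=O)NO)N(Cc1cn(CCOCCOCCOCCOc2cccnc2F)nn1)S(=O)(=O)c1ccc(OCCF)cc1` is compound 3 altered in one place: (2-fluoropyridin-3-yl)oxy in place of fluoro on a saturated chain carbon, two bonds along the chain from an oxygen on a saturated carbon. The rest of the molecule is left as it is, so the change sits at the far end of the chain. Among the measured compounds shown here, no measured pair shows this change, so its size is unknown here. The step from compound 3 to compound 4 is expected to be small, a 2.0-fold higher number from compound 3 to compound 4 (0.30 log units; within the scatter), within the scatter or a little toward weaker inhibition. Compound 4 is therefore estimated at 0.4 nM, with a range of 0.1 nM to 2 nM.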

Compound 4, half-maximal inhibitory concentration: 0.2 nM
Beside the measured number, compound 4's estimate is 2.0-fold (0.30 log units) above it; the range from low to high includes it.
By their numbers in this assay, from the lowest: compounds 3 and 4 (each within the scatter of the next); then compound 1; then compound 2.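

In this assay, putting (2-fluoropyridin-3-yl)oxy in place of fluoro on this saturated chain carbon gives no change at the digits printed from compound 3 to compound 4 (within the scatter). Among the compounds shown here, this position therefore accepts a six-membered aromatic ring in this one pair, which the earlier compounds could not show, since none of them differed from another in this one place alone. Nothing available here explains why the number holds steady.

Going by these compounds, whether a plain phenoxy group, without the ring nitrogen and ring fluorine, would fare the same remains open. So does the outcome with an amine or a carboxylic acid at this carbon.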